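Swapping the urea substituent on the piperidine-linked core

The compounds below may be only part of what the source reports. "The series", "measured", "known", "first", "only" and "open" are said of these compounds alone.

Compound 1 `O=C(NC1CCCCC1)N1CCN(c2nc(-c3ccc4ccccc4n3)no2)CC1`: in a functional assay on Shh Light II cells (Mus musculus) for inhibition, read by a luciferase reporter (on this read-out lower numbers stand for stronger inhibition and higher numbers for weaker inhibition), compound 1 gives 53 nM.
Compound 2 `O=C(NC1CCNCC1)N1CCC(c2nc(-c3ccc4ccccc4n3)no2)CC1`: in this assay compound 2 gives 2500 nM.
Compound 3 `O=C(N1CCC(c2nc(-c3ccc4ccccc4n3)no2)CC1)N1CCCc2ccccc21`: in this assay compound 3 gives 2300 nM.

Compound 3 stands second highest of the three numbers. Its nearest neighbour is compound 2, whose number lies within the usual scatter of it, so the two cannot be told apart; the furthest is compound 1, whose number is much lower, well beyond the scatter. Compound 4 `O=C(NC1CCOCC1)N1CCC(c2nc(-c3ccc4ccccc4n3)no2)CC1` arises from compound 3 by one change: (oxan-4-yl)amino in place of 1,2,3,4-tetrahydroquinolin-1-yl on a carbonyl carbon. Going by the values given here, only one measured step bears on this change, a 1.1-fold lower number from compound 2 to compound 3 (0.04 log units; within the scatter), in which the group on the same carbonyl carbon was exchanged with no effect beyond the scatter. Compound 1 differs from compound 2 in two places at once, so its much lower number cannot be tied to the urea substituent alone. A further exchange at the same position is therefore expected to give a step no larger than the scatter, a 1.3-fold lower number from compound 3 to compound 4 (0.11 log units; within the scatter). Compound 4 is estimated at 1800 nM, with a range from 600 nM to 5000 nM.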

Compound 4, half-maximal inhibitory concentration: 480 nM
Estimate against measurement, compound 4: 3.8-fold (0.57 log units) above; the measured number lies below the stated range.
By their numbers in this assay, from the lowest: compound 1; then compound 4; then compounds 3 and 2 (each within the scatter of the next).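

In this assay, the group on this carbonyl carbon turns out to matter: the earlier exchange gave only a 1.1-fold lower number from compound 2 to compound 3 (0.04 log units; within the scatter), whereas (oxan-4-yl)amino gives a 4.8-fold lower number from compound 3 to compound 4 (0.68 log units; beyond the scatter). The comparison with the piperidin-4-yl urea points the same way, since oxan-4-yl in place of piperidin-4-yl on the amide-type nitrogen gives a 5.2-fold lower number from compound 2 to compound 4 (0.72 log units; beyond the scatter), so two similar-looking rings are clearly told apart here. Nothing available explains why the oxan-4-yl compound gives the lower number.

Compound 1 still has the lowest number, but it differs from compound 4 in two places, so the compounds shown cannot say how much each place contributes. Also open, on these data alone, is whether an open chain such as 2-methoxyethylamino on this carbonyl carbon would keep the gain seen with the oxan-4-yl ring.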